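This account rests on a few compounds, and the source may have more. Where it says the series, first, only, none or still open, it means among the compounds named here.

Measured so far:
compound 1 `CO[C@@H]1CC=C2NN(c3cncnc3)C(=O)C[C@]2(c2ccccc2)O1` — 7330 nM
compound 2 `CO[C@@H]1CC=C2NN(c3cncnc3)C(=O)C[C@]2(C)O1` — 17100 nM

In a functional assay on DU-145 cells (Homo sapiens) for inhibition, read by sulforhodamine B assay, with a stated time of 48 h (on this read-out higher numbers stand for weaker inhibition and lower numbers for stronger inhibition), compound 1 holds the lowest of the two numbers; compound 2 differs from it by a 2.3-fold higher number from compound 1 to compound 2 (0.37 log units; beyond the scatter), a change at a saturated ring carbon. Compound 3 `CO[C@@H]1CC=C2NN(c3cc(F)cc(Cl)c3)C(=O)C[C@]2(c2ccccc2)O1` differs from compound 1 elsewhere: 3-chloro-5-fluorophenyl in place of pyrimidin-5-yl on an amide-type nitrogen in a ring. Within the data shown here, no measured step touches the group on the amide-type nitrogen, so nothing sizes this change. The expectation therefore rests on compound 1 alone, with a step of a 1.5-fold lower number from compound 1 to compound 3 (0.17 log units; within the scatter) that is expected to stay within the scatter. For compound 3 the estimate is 5000 nM in this assay, with a range of 1500 nM to 16000 nM.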

Compound 3, half-maximal inhibitory concentration: 16100 nM
The estimate for compound 3 lay 3.2-fold (0.51 log units) below the measured number; the measured number lies above the stated range.
By their numbers in this assay, from the lowest: compound 1; then compounds 3 and 2 (each within the scatter of the next).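

The group on the amide-type nitrogen in the ring now has a measured step: in this assay, 3-chloro-5-fluorophenyl in place of pyrimidin-5-yl gives a 2.2-fold higher number from compound 1 to compound 3 (0.34 log units; beyond the scatter), so this position responds to the change and pyrimidin-5-yl holds the lower number of the pair. No data on hand account for this step. The swap alters the ring atoms and the halogens together, so a plain phenyl or a pyridin-3-yl on this nitrogen would be needed to separate them. Also open, from the compounds shown here alone, is whether the step persists with the methyl of compound 2 in place of phenyl.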